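Swapping a Sulfonamide Arm for an Alcohol on a Shared Core

The source may report more compounds than this note shows. Statements on the series, on what has been measured and on what is new or still open speak of the compounds shown alone.

Three analogues sharing one core have been characterised in an assay for inhibition of 15-hydroxyprostaglandin dehydrogenase [NAD(+)] (Homo sapiens), read by fluorescence, with a stated time of 15 min, in the presence of a further agent that is not named here; on this read-out higher numbers stand for weaker inhibition and lower numbers for stronger inhibition. Compound 1, `CCCC[S+]([O-])c1sc2nc(-c3nccs3)cc(-c3ccc(C(=O)N(C)C)cc3)c2c1N`, gives 5.9 nM. Compound 2, `CCCC[S+]([O-])c1sc2nc(-c3nccs3)cc(-c3cccc(CO)c3)c2c1N`, gives 4.3 nM. Compound 3, `CCCC[S+]([O-])c1sc2nc(-c3nccs3)cc(-c3ccc(CNS(C)(=O)=O)cc3)c2c1N`, gives 4.6 nM. Compound 3 therefore stands second highest of the three numbers, yet its gap to compound 2 and its gap to compound 1 both fall within the scatter, so the three compounds cannot be ranked. Going by the values given here, the only measured single-point step is a 1.3-fold lower number from compound 1 to compound 3 (0.11 log units; within the scatter), which is likewise within the scatter.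

Compound 4, `CCCC[S+]([O-])c1sc2nc(-c3nccs3)cc(-c3ccc(CCO)cc3)c2c1N`, differs from compound 3 in one place: hydroxymethyl in place of methanesulfonamido on a saturated chain carbon bound to an aromatic carbon. Among the compounds with values here, no measured step covers a sulfonamide giving way to an alcohol at this position. Within the data shown here, the nearest guide is that compound 2, itself bearing a hydroxymethyl group, sits within the scatter of compound 3, and that the one measured change at this position, from compound 1 to compound 3, stayed within the scatter. Compound 4 is therefore expected to give 5 nM, with a range from 2.5 nM to 10 nM. The expected step of a 1.1-fold higher number from compound 3 to compound 4 (0.04 log units; within the scatter) should remain within the scatter.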

Compound 4, half-maximal inhibitory concentration: 2.9 nM
Beside the measured number, compound 4's estimate is 1.7-fold (0.24 log units) above it; low and high end bracket the measured number.
By their numbers in this assay, from the lowest: compounds 4, 2, 3 and 1 (each within the scatter of the next, the first and the last beyond it).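

Replacing (methanesulfonamido)methyl with 2-hydroxyethyl gives a 1.6-fold lower number from compound 3 to compound 4 (0.20 log units; within the scatter) in this assay, so this position accepts an alcohol in place of the sulfonamide with no loss on this read-out. Changing 3-(hydroxymethyl)phenyl to 4-(2-hydroxyethyl)phenyl gives a 1.5-fold lower number from compound 2 to compound 4 (0.17 log units; within the scatter), so this pair of alcohols cannot be told apart, although that change alters both the chain and where it sits. Going by these compounds alone, only the exchange of dimethylcarbamoyl for 2-hydroxyethyl, with a 2.0-fold lower number from compound 1 to compound 4 (0.31 log units; beyond the scatter), passes the scatter, and this is the first step in the set to do so, though only modestly.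

Nothing available explains these numbers. As far as these compounds go, it remains open how a primary amine, a carboxylic acid or a 3-hydroxypropyl chain would read at this place.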